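Working notes: substituent change from compound 3 to compound 4

The compounds below may be only part of what the source reports. "The series", "measured", "known", "first", "only" and "open" are said of these compounds alone.

Measured compounds in an assay on CHO cells for antagonist activity at transient receptor potential cation channel subfamily V member 1 (Homo sapiens), read by FLIPR; on this read-out higher numbers stand for weaker inhibition and lower numbers for stronger inhibition:
compound 1 `CC1CCN(c2cc(C(F)(F)F)ccc2CNC(=O)C(C)c2ccc(NS(C)(=O)=O)c(F)c2)CC1`: 0.9 nM
compound 2 `CC(C(=O)NCc1ccc(C(F)(F)F)cc1N1CCN(c2ccccc2)CC1)c1ccc(NS(C)(=O)=O)c(F)c1`: 2 nM
compound 3 `CC(C(=O)NCc1ccc(C(F)(F)F)cc1SC1CCCC1)c1ccc(NS(C)(=O)=O)c(F)c1`: 0.3 nM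

Compound 3 has the lowest number of the three, with a 3.0-fold lower number from compound 1 to compound 3 (0.48 log units; beyond the scatter) and a 6.7-fold lower number from compound 2 to compound 3 (0.82 log units; beyond the scatter); the remaining step is a 2.2-fold higher number from compound 1 to compound 2 (0.35 log units; beyond the scatter). All three steps are modest and concern the same aromatic carbon, which is also where compound 4 `CC(C(=O)NCc1ccc(C(F)(F)F)cc1Cl)c1ccc(NS(C)(=O)=O)c(F)c1` differs from compound 3: chloro in place of cyclopentylsulfanyl on an aromatic carbon. For the measured compounds named here, none of the measured steps replaces a six-atom ring-bearing group with a single atom, so the precedent is indirect; the three steps show this position moving the number by modest amounts in either direction. A modest rise from compound 3 is expected, a 10-fold higher number from compound 3 to compound 4 (1.00 log units; beyond the scatter). Compound 4 is estimated at 3 nM, with a range of 0.8 nM to 12 nM.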

Compound 4, inhibition constant: 4 nM
The estimate for compound 4 lay 1.3-fold (0.12 log units) below the measured number; low and high end bracket the measured number.
By their numbers in this assay, from the lowest: compound 3; then compound 1; then compounds 2 and 4 (each within the scatter of the next).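

In this assay, for the compounds shown here, chloro in place of cyclopentylsulfanyl gives a 13-fold higher number from compound 3 to compound 4 (1.12 log units; beyond the scatter), the first large step at this aromatic carbon. Chloro in place of 4-methylpiperidin-1-yl gives a 4.4-fold higher number from compound 1 to compound 4 (0.65 log units; beyond the scatter), whereas chloro in place of 4-phenylpiperazin-1-yl gives a 2.0-fold higher number from compound 2 to compound 4 (0.30 log units; within the scatter), so a single chlorine does not separate from every larger group here. No measurement at hand accounts for these steps.

Open, on these data alone, is whether the low number of compound 3 follows the sulfur or the five-membered ring. Methylsulfanyl or cyclopentylmethyl at this carbon would separate the two.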